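Dropping a cyclohexyloxy group from the most lipophilic compound

This account rests on a few compounds, and the source may have more. Where it says the series, first, only, none or still open, it means among the compounds named here.

Measured so far in a physicochemical assay for lipophilicity, at pH 7.4; on this read-out higher numbers stand for higher lipophilicity and lower numbers for lower lipophilicity:
compound 1 `CCc1ccc(N(CC(C)C)S(=O)(=O)c2ccc3c(c2)C(O)CC(C2CCN(S(C)(=O)=O)CC2)O3)cc1` gives 3.22
compound 2 `CCc1ccc(N(CC(C)C)S(=O)(=O)c2ccc3c(c2)C(OC2CCCCC2)CC(C2CCOCC2)O3)cc1` gives 6.28
compound 3 `CC(C)CN(c1ccccc1C(F)(F)F)S(=O)(=O)c1ccc2c(c1)C(O)CC(C1CCOCC1)O2` gives 4.14

Among these three numbers compound 2 stands highest in this assay. Its nearest neighbour is compound 3, whose value lies lower by a gap beyond the usual scatter, and compound 1 lies lower still, also well beyond the scatter. Compound 2 is therefore the clear top of this small set.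

The next compound, compound 4 `CCc1ccc(N(CC(C)C)S(=O)(=O)c2ccc3c(c2)CCC(C2CCOCC2)O3)cc1`, is drawn directly from compound 2. The change is hydrogen in place of cyclohexyloxy on a saturated ring carbon. For the measured compounds named here, no step between two measured compounds covers this exact exchange, so the expectation rests on the size of the group that leaves and on where the three measured values sit.

A group of seven heavy atoms, six of them carbon, is taken away and nothing but a hydrogen atom put in its place. In this assay a downward step of considerable size is expected, well beyond the scatter, and the estimated step of a number 1.88 log units lower from compound 2 to compound 4 (beyond the scatter) reflects that. For compound 4 the estimate in this assay is 4.4, expected to fall between 3.8 and 5.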

Compound 4, distribution coefficient: 5.38
Estimate against measurement, compound 4: 0.98 log units below; measured number above the stated range.
By their numbers in this assay, from the lowest: compound 1; then compound 3; then compound 4; then compound 2.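

In this assay, for the compounds shown here, hydrogen in place of cyclohexyloxy on a saturated ring carbon gives the first step in this set that changes a single place, and it comes out as a number 0.90 log units lower from compound 2 to compound 4 (beyond the scatter). The group that leaves has 7 heavy atoms (6 carbon, 1 oxygen) and includes a six-membered non-aromatic ring of carbon only, yet the step is modest, and compound 4, with only hydrogen at this position, still gives 5.38. Nothing shown here accounts for the size of this step.

One open question is how a hydroxy group at this ring carbon would compare on an otherwise identical structure, as compound 1 and compound 3 both carry one there but also differ from compound 2 and compound 4 elsewhere. Also open, on these data alone, are where a methoxy group or an amine at the same position would fall relative to hydrogen and cyclohexyloxy, and whether the same exchange would give a step of similar size with the trifluoromethyl-bearing aryl group of compound 3.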